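The compounds below may be only part of what the source reports. "The series", "measured", "known", "first", "only" and "open" are said of these compounds alone.

Working notes on the series in a functional assay on NCI-H460 cells (Homo sapiens) for antiproliferative activity, read by XTT assay, with a stated time of 72 h; a lower number here means a stronger inhibitor, a higher number a weaker inhibitor.

Three measured compounds share one core and differ only in the aryl group on the carbonyl carbon. Compound 1 `COc1ccc(-c2cc3ccccc3nc2/C=C/C(=O)c2ccc(F)cc2)cc1` gives 6990 nM. Compound 2 `COc1ccc(-c2cc3ccccc3nc2/C=C/C(=O)c2ccc(N)cc2)cc1` gives 7400 nM. Compound 3 `COc1ccc(-c2cc3ccccc3nc2/C=C/C(=O)c2ccc([N+](=O)[O-])cc2)cc1` gives 6470 nM. Compound 3 holds the lowest of the three numbers, but its neighbours sit close: a 1.1-fold lower number from compound 1 to compound 3 (0.03 log units; within the scatter) and a 1.1-fold lower number from compound 2 to compound 3 (0.06 log units; within the scatter), so the three values show no separation.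

Compound 4 `COc1ccc(-c2cc3ccccc3nc2/C=C/C(=O)c2ccsc2)cc1` is the next member, not yet measured. Its change from compound 3 is thiophen-3-yl in place of 4-nitrophenyl on a carbonyl carbon. The measured steps that bear on it are those at the same carbonyl carbon: a 1.1-fold higher number from compound 1 to compound 2 (0.02 log units; within the scatter), a 1.1-fold lower number from compound 1 to compound 3 (0.03 log units; within the scatter) and a 1.1-fold lower number from compound 2 to compound 3 (0.06 log units; within the scatter). Each of them swaps one group on the aryl ring and each stays inside the scatter. Among the measured compounds shown here, the step to compound 4 is of a different kind, since the aryl ring itself is exchanged, so no direct precedent exists; the series offers no evidence that this position moves the number at all.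

The expectation for compound 4 is therefore no step beyond the scatter, a 1.1-fold higher number from compound 3 to compound 4 (0.03 log units; within the scatter), with a wider range to cover the untested ring exchange. Compound 4 is estimated at 7000 nM, between 3000 nM and 16000 nM.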

Compound 4, half-maximal inhibitory concentration: 7080 nM
For compound 4 the middle estimate is 1.0-fold (0.00 log units) below the measured one; the measured number falls inside the stated range.
By their numbers in this assay, from the lowest: compounds 3, 1, 4 and 2 (each within the scatter of the next).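

The ring exchange on the carbonyl carbon leaves the number in this assay inside the scatter against all three earlier aryl groups: thiophen-3-yl for 4-nitrophenyl (a 1.1-fold higher number from compound 3 to compound 4 (0.04 log units; within the scatter)), for 4-aminophenyl (a 1.0-fold lower number from compound 2 to compound 4 (0.02 log units; within the scatter)) and for 4-fluorophenyl (a 1.0-fold higher number from compound 1 to compound 4 (0.01 log units; within the scatter)). Among the compounds shown here, the earlier compounds showed only that the group on a six-membered aromatic ring of carbon could be swapped without a step beyond the scatter; compound 4 extends this to the ring itself, with a five-membered aromatic ring holding one sulfur atom and fewer heavy atoms than 4-nitrophenyl. No measurement offers an explanation for this insensitivity to the change.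

All four compounds carry an aromatic ring on the carbonyl carbon and none stands apart from the others, so the series does not yet show any group at this position that moves the number beyond the scatter. Open questions are whether a saturated ring such as cyclohexyl, a short chain such as methyl or a phenyl bearing a carboxylic acid would do so, and how changes elsewhere on the shared core would read.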